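The source may hold more compounds than are shown below. What is called first, only, known or untested is meant among the compounds shown, and "the series" means these compounds.

This study follows a small set of related compounds in a functional assay on MCF7 cells (Homo sapiens) for antiproliferative activity, read by MTT assay, with a stated time of 72 h; on this read-out lower numbers stand for stronger inhibition and higher numbers for weaker inhibition. Compound 2 `COc1ncc(-c2ccc3c(c2)N(C2CCCCC2)C(=O)CO3)cc1NS(=O)(=O)c1ccc(F)cc1` gives 30100 nM, and compound 1 `COc1ncc(-c2ccc3c(c2)N(c2ccc(C)cc2)C(=O)CO3)cc1NS(=O)(=O)c1ccc(F)cc1` gives 15400 nM. The step between them, a 2.0-fold lower number from compound 2 to compound 1 (0.29 log units; within the scatter), corresponds to the change (4-methylphenyl in place of cyclohexyl on an amide-type nitrogen in a ring).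

Compound 3 `O=C1COc2ccc(-c3cnc4ccccc4c3)cc2N1C1CCCCC1` is built on a different core; the difference between the core of compound 2 and the core of compound 3 is not broken down here. In this assay compound 3 reaches only the limit, > 40000 nM, which is a limit of the assay and not a number. This is recorded in the limit of > 40000 nM in this assay, at which 1 of the 3 values shown sits.

Compound 4 `Cc1ccc(N2C(=O)COc3ccc(-c4cnc5ccccc5c4)cc32)cc1` has not yet been measured in this assay. It differs from compound 3 by 4-methylphenyl in place of cyclohexyl on an amide-type nitrogen in a ring, the same change that separates compound 2 from compound 1, made at the same place. On the measured pair this change gave a 2.0-fold lower number from compound 2 to compound 1 (0.29 log units; within the scatter), a step that stays within the usual scatter.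

The step from compound 3 to compound 4 is expected to be of similar size, because compound 3 stands at > 40000 nM and the same change produced only a 2.0-fold lower number from compound 2 to compound 1 (0.29 log units; within the scatter). The expected step is an at least 1.1-fold lower number from compound 3 to compound 4 (0.05 log units; that floor lies within the scatter). Compound 4 is therefore estimated to give about 35000 nM, with a plausible range from 15000 nM to 80000 nM, and a real chance that this assay again reports only a limit for compound 4.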

Compound 4, half-maximal inhibitory concentration: > 40000 nM
Compound 4 gave a limit, no number (the forecaster's own chance of this, stated with the estimate: 55%); middle value at least 1.1-fold (0.05 log units) away from the limit.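

Compound 4, like compound 3, gives only a limit of the assay and not a number, so no step can be read from compound 3 to compound 4: the limit of > 40000 nM in this assay, at which 2 of the 4 values shown sit.

The compounds shown leave open whether 4-methylphenyl in place of cyclohexyl on the amide-type nitrogen changes the read-out at all on the core of compound 3, where neither compound has a number.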